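Moving the halogen on the benzyl ether: from chloro to 4-fluoro

A few compounds are considered here, and "the series" means these few. Any claim that something is new, unique, unknown or untested is made for them only; others in the source may bear on it.

Compound 1 `N#Cc1ccc(Nc2nccc(OCc3ccccc3Cl)n2)cc1` gives 146000 nM in an ADME assay on MT4 cells (Homo sapiens) for cytotoxicity, read by MTT assay, with a stated time of 5 days (on this read-out lower numbers stand for higher toxicity in this test and higher numbers for lower toxicity in this test), the second highest of the three numbers. Compound 2 `N#Cc1ccc(Nc2nccc(OCc3cccc(Cl)c3)n2)cc1` gives 153000 nM, and a 1.0-fold higher number from compound 1 to compound 2 (0.02 log units; within the scatter). Compound 3 `N#Cc1ccc(Nc2nccc(OCc3ccc(Br)cc3)n2)cc1` gives 16000 nM; here a 9.1-fold lower number from compound 1 to compound 3 (0.96 log units; beyond the scatter) and a 9.6-fold lower number from compound 2 to compound 3 (0.98 log units; beyond the scatter). Compound 4 `N#Cc1ccc(Nc2nccc(OCc3ccc(F)cc3)n2)cc1` differs from compound 1 by 4-fluorophenyl in place of 2-chlorophenyl on a saturated chain carbon bound to an oxygen on an aromatic ring. Among the measured compounds shown here, the steps to compound 3 bear on this change most closely, as each exchanged a chlorophenyl for a 4-bromophenyl, yet no measured pair compares a 4-bromophenyl with a 4-fluorophenyl, so the bromine result may not carry over. A step to a lower number in this assay is expected for compound 4, probably smaller than a 9.1-fold lower number from compound 1 to compound 3 (0.96 log units; beyond the scatter). Compound 4 is estimated at 60000 nM, with a range of 15000 nM to 170000 nM. That estimate corresponds to an expected 2.4-fold lower number from compound 1 to compound 4 (0.39 log units; beyond the scatter).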

Compound 4, half-maximal cytotoxic concentration: 81000 nM
The estimate for compound 4 lay 1.4-fold (0.13 log units) below the measured number; the range from low to high includes it.
By their numbers in this assay, from the lowest: compound 3; then compounds 4, 1 and 2 (each within the scatter of the next).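

In this assay, among the compounds shown here, fluoro in place of bromo on an aromatic carbon gives the first comparison with the ring substitution otherwise unchanged (a 5.1-fold higher number from compound 3 to compound 4 (0.70 log units; beyond the scatter)), so the low number of compound 3 is not shared by the 4-fluorophenyl compound. Compound 4 cannot be told apart from either chlorophenyl compound (a 1.8-fold lower number from compound 1 to compound 4 (0.26 log units; within the scatter)) and (a 1.9-fold lower number from compound 2 to compound 4 (0.28 log units; within the scatter)). Nothing available here gives a cause for these steps.

From the compounds shown here alone, whether a 4-chlorophenyl group would sit with compound 3 or with compound 4 stays open. So does the effect of an amine on the ring or a longer chain at the ether carbon.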